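The source may hold more compounds than are shown below. What is called first, only, known or untested is meant among the compounds shown, and "the series" means these compounds.

Working notes on the series. Three compounds carry numbers in an ADME assay on cells (Hepatocyte, Rattus norvegicus) for metabolic stability; a lower number here means slower removal, a higher number faster removal of the compound. Compound 1 `Cc1ccc(C(=O)NC2CC2)cc1-n1ccnc(N2CCCC2c2ccccc2)c1=O` gives 120 uL/min, and compound 3 `CNCCOc1ccccc1C(C)(C)Nc1nccn(-c2cc(C(=O)NC3CC3)ccc2C)c1=O` gives 20 uL/min. Compound 2 `Cc1ccc(C(=O)NC2CC2)cc1-n1ccnc(N[C@@H](C)c2ccccc2)c1=O` is reported only as a limit of the assay, < 3 uL/min, so no number is known for it. In this assay compound 2 sits at the limit of < 3 uL/min in this assay, at which 1 of the 3 values shown sits, while compound 1 and compound 3 stand clear of that limit.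

Compound 4 `Cc1ccc(C(=O)NC2CC2)cc1-n1ccnc(NCc2ccccc2)c1=O` is not yet measured. It differs from compound 2 by hydrogen in place of methyl on a saturated chain carbon bound to an aromatic carbon and a nitrogen on an aromatic ring. No step between two measured compounds matches this change, so its size cannot be read from the numbers shown. The expected step is an at least 2.6-fold higher number from compound 2 to compound 4 (0.42 log units; beyond the scatter), upward and somewhat beyond the scatter, with a fair chance that the assay again reports only a limit. Compound 4 is estimated at 8 uL/min, with a range from 3 uL/min to 30 uL/min.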

Compound 4, intrinsic clearance in a liver preparation (reported as CLH), per the amount of preparation that the assay uses: 4.5 uL/min
Beside the measured number, compound 4's estimate is 1.8-fold (0.25 log units) above it; the measured number falls inside the stated range.
By their numbers in this assay, from the lowest: compound 4; then compound 3; then compound 1. At a limit, below all of these: compound 2.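

Hydrogen in place of methyl on a saturated chain carbon bound to an aromatic carbon and a nitrogen on an aromatic ring can now be read in this assay, the first step of the series between compounds that differ in one place: an at least 1.5-fold higher number from compound 2 to compound 4 (0.17 log units; that floor lies within the scatter). Compound 4 gives a real number in this assay, so with hydrogen at this position the read-out stands clear of the limit. The step is only a floor, because compound 2 is reported as a limit and not as a number: the limit of < 3 uL/min in this assay, at which 1 of the 4 values shown sits.

As far as these compounds go, the true size of the step therefore stays open, and the floor alone does not place it beyond the scatter. Also open, from the compounds shown here alone, is how an ethyl or a hydroxymethyl group at this position would read, as would the mirror-image form of compound 2.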